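The source may hold more compounds than are shown below. What is called first, only, known or untested is meant among the compounds shown, and "the series" means these compounds.

Measured so far in a physicochemical assay for lipophilicity; on this read-out higher numbers stand for higher lipophilicity and lower numbers for lower lipophilicity:
compound 1, `COc1ccc(C2=NO[C@]3(C2)C(=O)O[C@@H]2[C@H]3CC[C@H](C)[C@]3(O)C=CC(=O)[C@@]23C)cc1`: 1.47
compound 2, `C[C@H]1CC[C@@H]2[C@@H](OC(=O)[C@]23CC(c2ccccc2Br)=NO3)[C@]2(C)C(=O)C=C[C@@]12O`: 2.22
compound 3, `C[C@H]1CC[C@@H]2[C@@H](OC(=O)[C@]23CC(c2ccc(O)cc2)=NO3)[C@]2(C)C(=O)C=C[C@@]12O`: 0.932

Compound 3 stands lowest of the three numbers in this assay; its nearest neighbour is compound 1, its furthest compound 2, both higher and beyond the scatter. Compound 4, `Cc1ccccc1C1=NO[C@]2(C1)C(=O)O[C@@H]1[C@H]2CC[C@H](C)[C@]2(O)C=CC(=O)[C@@]12C`, is not yet measured. It differs from compound 3 in one place: 2-methylphenyl in place of 4-hydroxyphenyl on a carbon with a double bond to nitrogen.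

Among the compounds with values here, two measured steps bear on this change. The reverse of the change at the same position is a number 1.29 log units lower from compound 2 to compound 3 (beyond the scatter), a large step, where a bromine-bearing ring rather than a methyl-bearing ring was involved. Removal of the methyl from the oxygen alone gave a number 0.54 log units lower from compound 1 to compound 3 (beyond the scatter), modest. Both point the same way: loss of the phenolic hydrogen-bond donor and acceptor in going from compound 3 to compound 4 is expected to raise the number in this assay by a large step, somewhat below the full size of the bromine case, a number 1.17 log units higher from compound 3 to compound 4 (beyond the scatter). Compound 4 is therefore estimated at 2.1, in the range 1.7 to 2.5.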

Compound 4, partition coefficient: 1.86
Beside the measured number, compound 4's estimate is 0.24 log units above it, within the range that was stated.
By their numbers in this assay, from the lowest: compound 3; then compound 1; then compound 4; then compound 2.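

In this assay the swap on the carbon with a double bond to nitrogen gives a number 0.93 log units higher from compound 3 to compound 4 (beyond the scatter) when 2-methylphenyl replaces 4-hydroxyphenyl, so a gain at this position does not depend on the entering ring carrying bromo. Methyl in place of bromo on the aromatic carbon gives a number 0.36 log units lower from compound 2 to compound 4 (beyond the scatter) and separates the two 2-substituted rings beyond the scatter. With a number 0.39 log units higher from compound 1 to compound 4 (beyond the scatter) as 2-methylphenyl replaces 4-methoxyphenyl, the four rings on the shared core now stand in one order, from 4-hydroxyphenyl through 4-methoxyphenyl and 2-methylphenyl to 2-bromophenyl.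

As far as these compounds go, how a phenyl ring carrying an amine or a carboxylic acid would fall in this order remains open. No measurement here accounts for the size of these steps.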